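Exchanging the aryl group on the amine nitrogen

This account rests on a few compounds, and the source may have more. Where it says the series, first, only, none or still open, it means among the compounds named here.

Compound 1 `COc1ccc(NCn2nc(-c3ccc4c(c3)OCCO4)oc2=S)cc1`, in a functional assay, with a stated time of 6 min; on this read-out lower numbers stand for stronger inhibition and higher numbers for weaker inhibition: 5830 nM
Compound 2 `S=c1oc(-c2ccc3c(c2)OCCO3)nn1CNC1CCCCC1`, in this assay: 18400 nM
Compound 3 `Fc1ccc(NCn2nc(-c3ccc4c(c3)OCCO4)oc2=S)cc1`, in this assay: 6480 nM

Compound 1 has the lowest number of the three; compound 3 stands within the scatter of it, while compound 2 lies beyond it (a 3.2-fold higher number from compound 1 to compound 2 (0.50 log units; beyond the scatter)). Compound 4 `S=c1oc(-c2ccc3c(c2)OCCO3)nn1CNc1ccccc1Br` is not yet measured and differs from compound 1 in one place: 2-bromophenyl in place of 4-methoxyphenyl on an amine nitrogen. Two kinds of measured step bear on this change. Swapping one aromatic ring on the amine nitrogen for another, a 1.1-fold higher number from compound 1 to compound 3 (0.05 log units; within the scatter), stayed within the scatter, whereas putting cyclohexyl in place of the aromatic ring, a 3.2-fold higher number from compound 1 to compound 2 (0.50 log units; beyond the scatter), raised the number well beyond it, and the reverse change, a 2.8-fold lower number from compound 2 to compound 3 (0.45 log units; beyond the scatter), brought it down again. Compound 4 keeps an aromatic ring at that position, so the step in this assay is expected to be small, plausibly in either direction and most likely within the scatter. For compound 4 the estimate is 7000 nM, with a range from 3500 nM to 14000 nM, which corresponds to an expected step of a 1.2-fold higher number from compound 1 to compound 4 (0.08 log units; within the scatter).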

Compound 4, half-maximal inhibitory concentration: 12700 nM
Compound 4: middle estimate off by 1.8-fold (0.26 log units), on the low side; measured number inside the range.
By their numbers in this assay, from the lowest: compounds 1, 3, 4 and 2 (each within the scatter of the next, the first and the last beyond it).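

In this assay, keeping an aromatic ring on the amine nitrogen did not by itself hold the number at the level of compound 1, since the 2-bromophenyl exchange gave a 2.2-fold higher number from compound 1 to compound 4 (0.34 log units; beyond the scatter), whereas the 4-fluorophenyl exchange had stayed within the scatter. Against the other two compounds the same group gave a 2.0-fold higher number from compound 3 to compound 4 (0.29 log units; within the scatter) and a 1.4-fold lower number from compound 2 to compound 4 (0.16 log units; within the scatter), so compound 4 cannot be told apart from either one, although compound 2 and compound 3 themselves are separated by a 2.8-fold lower number from compound 2 to compound 3 (0.45 log units; beyond the scatter). No measurement is available that bears on what lies behind this step.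

As far as these compounds go, how unsubstituted phenyl or 2-chlorophenyl on the amine nitrogen would read remains open, and with it whether the step belongs to the bromine. Also open, from the compounds shown here alone, is where a pyridine ring or a short alkyl chain at this position would fall.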